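Swapping the ring-nitrogen aryl group in a trimethoxybenzyl series

The source may hold more compounds than are shown below. What is called first, only, known or untested is meant among the compounds shown, and "the series" means these compounds.

Two compounds of this series have been examined in an ADME assay on CCRF-CEM cells (Homo sapiens) for cytotoxicity, read by MTT assay, with a stated time of 5 days; on this read-out lower numbers stand for higher toxicity in this test and higher numbers for lower toxicity in this test. Compound 1 `COc1cc(Cc2cnc(/N=C3\C(=O)N(CN4CCN(Cc5ccccc5)CC4)c4ccc(Cl)cc43)nc2N)cc(OC)c1OC` gives 94.7 ug/mL in this assay. Within the data shown here, compound 2 `COc1cc(Cc2cnc(/N=C3\C(=O)N(CN4CCN(c5ccccn5)CC4)c4ccc(Cl)cc43)nc2N)cc(OC)c1OC` gives 29.4 ug/mL, which is the lowest of the two numbers so far; the only measured step, a 3.2-fold lower number from compound 1 to compound 2 (0.51 log units; beyond the scatter), was obtained by putting pyridin-2-yl in place of benzyl on an amine nitrogen in a ring.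

Compound 3 `COc1cccc(N2CCN(CN3C(=O)/C(=N\c4ncc(Cc5cc(OC)c(OC)c(OC)c5)c(N)n4)c4cc(Cl)ccc43)CC2)c1` has not yet been measured. Among the measured compounds shown here, it differs from compound 2 by 3-methoxyphenyl in place of pyridin-2-yl on an amine nitrogen in a ring, at the same position where the one measured step was made. That step was modest and of a different kind of change, so it offers only a loose guide. On that basis compound 3 is expected to stay close to compound 2 in this assay, with the step of a 1.2-fold higher number from compound 2 to compound 3 (0.08 log units; within the scatter) estimated to lie within the scatter rather than clearly in either direction. The estimate for compound 3 is therefore 35 ug/mL, expected to fall between 12 ug/mL and 100 ug/mL.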

Compound 3, half-maximal cytotoxic concentration: 23.3 ug/mL
Beside the measured number, compound 3's estimate is 1.5-fold (0.18 log units) above it; the measured number falls inside the stated range.
By their numbers in this assay, from the lowest: compounds 3 and 2 (each within the scatter of the next); then compound 1.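

In this assay, replacing pyridin-2-yl with 3-methoxyphenyl on the amine nitrogen in the ring gives a 1.3-fold lower number from compound 2 to compound 3 (0.10 log units; within the scatter). At this position, then, a six-membered aromatic ring with one hetero atom and a larger one of carbon only, carrying methoxy, cannot be told apart in this test, even though the entering group has more heavy atoms. The earlier step could not show this, but the new comparison with benzyl gives a 4.1-fold lower number from compound 1 to compound 3 (0.61 log units; beyond the scatter), which sits alongside a 3.2-fold lower number from compound 1 to compound 2 (0.51 log units; beyond the scatter), so among these three compounds, compound 1 with benzyl stands apart from the other two, and no compound here goes against that. No measurement shown offers a reason for any of these steps.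

The compounds shown leave open how this assay would read for a plain phenyl on this nitrogen, or for a phenyl ring carrying an amine or a carboxylic acid in place of methoxy. They also leave open whether a longer chain than that of benzyl, ending in the same aromatic ring, would remain apart from compound 2 and compound 3.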